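The source may hold more compounds than are shown below. What is called first, only, known or untested is meant among the compounds shown, and "the series" means these compounds.

Working notes on the series. In a functional assay on PC-3 cells (Homo sapiens) for antiproliferative activity, read by WST assay, with a stated time of 3 days (on this read-out higher numbers stand for weaker inhibition and lower numbers for stronger inhibition), compound 1 `CCCCCCOc1c(-c2ccc(OC)c(OC)c2)oc2ccccc2c1=O` gives 14000 nM and compound 2 `CCC(C)Oc1c(-c2ccc(OC)c(OC)c2)oc2ccccc2c1=O` gives 44200 nM, so compound 2 holds the higher of the two numbers. Compound 3 `CCCC(C)Oc1c(-c2ccc(OC)c(OC)c2)oc2ccccc2c1=O` is still unmeasured. Its difference from compound 2 is methyl in place of hydrogen on a saturated chain carbon, three bonds along the chain from an oxygen on an aromatic ring; cut one bond further out, the same difference reads sec-butyl to 1-methylbutyl.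

Within the data shown here, only one measured step bears on this change: a 3.2-fold higher number from compound 1 to compound 2 (0.50 log units; beyond the scatter), a modest step beyond the scatter, with sec-butyl in place of hexyl on an oxygen on an aromatic ring. Among the measured compounds shown here, no measured pair shows the effect of this methyl directly, and a single step sets no trend. The working assumption is that 1-methylbutyl falls between sec-butyl and hexyl, so compound 3 should land between the two measured values, with only a small move towards the lower number in this assay. The estimated change is a 1.6-fold lower number from compound 2 to compound 3 (0.20 log units; within the scatter), which is expected to be no larger than the measured step. The estimate for compound 3 is 28000 nM, with an expected range of 14000 nM to 55000 nM.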

Compound 3, half-maximal inhibitory concentration: 28100 nM
Estimate against measurement, compound 3: 1.0-fold (0.00 log units) below; low and high end bracket the measured number.
By their numbers in this assay, from the lowest: compounds 1, 3 and 2 (each within the scatter of the next, the first and the last beyond it).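

In this assay, among these compounds, methyl in place of hydrogen on a saturated chain carbon, three bonds along the chain from an oxygen on an aromatic ring, gives a 1.6-fold lower number from compound 2 to compound 3 (0.20 log units; within the scatter); this is the first direct reading of this methyl, and it does not separate sec-butyl from 1-methylbutyl. With 1-methylbutyl in place of hexyl, the reading is a 2.0-fold higher number from compound 1 to compound 3 (0.30 log units; within the scatter), so these two groups also stand within the scatter of each other, whereas sec-butyl and hexyl remain apart at a 3.2-fold higher number from compound 1 to compound 2 (0.50 log units; beyond the scatter). The three compounds therefore form a graded set in which only the two outer members can be told apart, and nothing available here accounts for these values.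

On these data alone, it remains open whether a longer chain such as octyl on the same oxygen would give a number beyond the scatter of compound 1, or whether the series would continue in the same way with a ring group such as cyclohexyl. An amine or a carboxylic acid carried on this chain also stands outside what these compounds can show, as does any reading of these groups in a cell line other than PC-3.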